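Replacing a phenyl ring with a naphthalene ring

The source may hold more compounds than are shown below. What is called first, only, known or untested is meant among the compounds shown, and "the series" means these compounds.

Three sulfonamide analogues share one core and differ only in the aromatic group on a chain carbon bound to an amine nitrogen. In a functional assay on PANC-1 cells (Homo sapiens) for inhibition, read by MTT assay, with a stated time of 72 h (on this read-out lower numbers stand for stronger inhibition of growth and higher numbers for weaker inhibition of growth), compound 1 `O=S(=O)(NCCCNCc1ccc(Cl)c(Cl)c1)c1cc(C(F)(F)F)cc(C(F)(F)F)c1` gives 5600 nM. Compound 2 `O=S(=O)(NCCCNCc1ccc(Cl)c(C(F)(F)F)c1)c1cc(C(F)(F)F)cc(C(F)(F)F)c1` gives 10000 nM. Compound 3 `O=S(=O)(NCCCNCc1ccccc1)c1cc(C(F)(F)F)cc(C(F)(F)F)c1` gives 16000 nM, the highest of the three numbers. The step of a 2.9-fold higher number from compound 1 to compound 3 (0.46 log units; beyond the scatter) lies beyond the scatter, whereas a 1.6-fold higher number from compound 2 to compound 3 (0.20 log units; within the scatter) does not. Compound 4 `O=S(=O)(NCCCNCc1cccc2ccccc12)c1cc(C(F)(F)F)cc(C(F)(F)F)c1` carries naphthalen-1-yl in place of phenyl on a saturated chain carbon bound to an amine nitrogen. Both steps into compound 3 bear on this change: one shows the bare phenyl inhibiting growth less than a substituted ring, the other shows no difference beyond the scatter. A modest downward step is therefore expected, about a 2.0-fold lower number from compound 3 to compound 4 (0.30 log units; within the scatter). Compound 4 is estimated at 8000 nM, ranging from 3500 nM to 18000 nM.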

Compound 4, concentration for 50% growth inhibition: 2700 nM
Compound 4: middle estimate off by 3.0-fold (0.47 log units), on the high side; measured number below the stated range.
By their numbers in this assay, from the lowest: compound 4; then compounds 1, 2 and 3 (each within the scatter of the next, the first and the last beyond it).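

At this position on a saturated chain carbon bound to an amine nitrogen, a second six-membered aromatic ring gives stronger inhibition of growth (a 5.9-fold lower number from compound 3 to compound 4 (0.77 log units; beyond the scatter)). The carbon-only naphthalen-1-yl group also outperforms both halogen-bearing rings (a 3.7-fold lower number from compound 2 to compound 4 (0.57 log units; beyond the scatter); a 2.1-fold lower number from compound 1 to compound 4 (0.32 log units; beyond the scatter)), making compound 4 the strongest of the four, so no chloro or trifluoromethyl group is needed here. No available evidence explains this gain. From the compounds shown here alone, whether naphthalen-2-yl would perform as well remains open, as does whether a chloro group on the naphthalen-1-yl ring would add anything further.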